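Iodo in place of ethynyl at the assay limit

A few compounds are considered here, and "the series" means these few. Any claim that something is new, unique, unknown or untested is made for them only; others in the source may bear on it.

Compound 1 `Cc1nc(N)c2c(-c3cccs3)cn([C@@H]3O[C@H](CO)[C@@H](O)[C@H]3O)c2n1` and compound 2 `C#Cc1cn([C@@H]2O[C@H](CO)[C@@H](O)[C@H]2O)c2nc(C)nc(N)c12` share one core and differ at a single aromatic carbon. In a functional assay on HeLa S3 cells (Homo sapiens) for antiproliferative activity, read by XTT assay, with a stated time of 72 h (a higher number here means a weaker inhibitor, a lower number a stronger inhibitor), compound 1 gives > 20000 nM, which is a limit and not a number. Compound 2 gives > 20000 nM, also a limit. The pair thus stands at the limit of > 20000 nM in this assay, at which 2 of the 2 values shown sit, and compound 2 has no measured potency to start from.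

Compound 3 `Cc1nc(N)c2c(I)cn([C@@H]3O[C@H](CO)[C@@H](O)[C@H]3O)c2n1` carries iodo in place of ethynyl on the same aromatic carbon: iodo in place of ethynyl on an aromatic carbon. For the measured compounds named here, the only measured step at this carbon is a step that the two limits leave unreadable from compound 1 to compound 2, so it offers no size to carry over. Neither substituent tried there has given a number in this assay, so compound 3 is expected to stay near the limit, with no clear shift in either direction. The estimated change is a number no higher from compound 2 to compound 3 (the limit leaves the size open). Compound 3 is estimated at 20000 nM, with an expected range from 5000 nM to 30000 nM.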

Compound 3, half-maximal inhibitory concentration: 4180 nM
Estimate against measurement, compound 3: 4.8-fold (0.68 log units) above; the whole stated range lies above it.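

In this assay, for the compounds shown here, this aromatic carbon now gives a readable change for the first time: iodo brings an at least 4.7-fold lower number from compound 2 to compound 3 (0.67 log units; beyond the scatter), and set against thiophen-2-yl it brings an at least 4.7-fold lower number from compound 1 to compound 3 (0.67 log units; beyond the scatter). Both steps are bounded on one side only, and the step between compound 1 and compound 2 cannot be read. The substituent on this carbon therefore does matter in this series, since only iodo among the three groups tried moves the value off the limit, where ethynyl and thiophen-2-yl stay: the limit of > 20000 nM in this assay, at which 2 of the 3 values shown sit.

As far as these compounds go, whether bromo, chloro or an amine on this same carbon would give a number near that of compound 3 stays open. Also open, from the compounds shown here alone, is whether the step from iodo holds when the methyl group on the shared core is replaced by a longer chain.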